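Lengthening and shortening the chain of a selenium sulfate

The compounds below may be only part of what the source reports. "The series", "measured", "known", "first", "only" and "open" are said of these compounds alone.

compound 1 `O=S(=O)(O)OCCCCCCCCCC[Se]c1ccccc1`: > 100000 nM
compound 2 `O=S(=O)(O)OCCCCCCCCCC[Te]c1ccccc1`: 5320 nM
compound 3 `O=S(=O)(O)OCCCCCCCCCCC[Se]c1ccccc1`: > 100000 nM

In a functional assay on RAW264.7 cells (Mus musculus) for cytotoxicity, read by MTT assay, with a stated time of 24 h (a lower number here means a stronger inhibitor, a higher number a weaker inhibitor), compound 1 stands at > 100000 nM, which is a limit and not a number. Compound 3 gives > 100000 nM, which is also a limit. Compound 4 `O=S(=O)(O)OCCCCCCCC[Se]c1ccccc1` has not yet been measured, and its change is sulfooxy in place of 2-(sulfooxy)ethyl on a saturated chain carbon, eight bonds along the chain from a selenium atom. This is sulfooxy in place of 2-(sulfooxy)ethyl, a shorter chain. The nearest measured change is a step that the two limits leave unreadable from compound 1 to compound 3, so it gives no size to carry over. The other measured change, an at least 18-fold lower number from compound 1 to compound 2 (1.27 log units; beyond the scatter), is of a different kind and does not bear on chain length. No step beyond the scatter is therefore expected, and the expected step is a number no higher from compound 1 to compound 4 (the limit leaves the size open). Compound 4 is expected at 100000 nM, with an estimated range of 30000 nM to 200000 nM.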

Compound 4, half-maximal inhibitory concentration: > 100000 nM
Compound 4: only a limit was reported (the forecaster's own chance of this, stated with the estimate: 80%); the middle value sits exactly at the limit.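

Among the compounds shown here, compound 1 and compound 4 each give only a limit in this assay, so no step between them can be read: the limit of > 100000 nM in this assay, at which 3 of the 4 values shown sit. The compounds shown leave open whether chain length changes this read-out at all among the selenium sulfates.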